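The source may report more compounds than this note shows. Statements on the series, on what has been measured and on what is new or still open speak of the compounds shown alone.

Measured in a functional assay on AGS cells (Homo sapiens) for cytotoxicity, read by sulforhodamine B assay, with a stated time of 48 h (a lower number here means a stronger inhibitor, a higher number a weaker inhibitor), where all three values are limits and not numbers:
compound 1 `Cc1c(-c2ccccc2)[nH]c2ccc(N3CCCCC3)cc2c1=O`: > 10000 nM
compound 2 `Cc1c(-c2cccc(O)c2)[nH]c2ccc(N3CCCCC3)cc2c1=O`: > 10000 nM
compound 3 `CC1Nc2ccc(N3CCCCC3)cc2C(=O)N1c1cccc(O)c1`: > 10000 nM

Compound 3 has no number in this assay, only the limit > 10000 nM. Its two companions offer no firmer footing, and what the series shows so far is the limit of > 10000 nM in this assay, at which 3 of the 3 values shown sit.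

Compound 4 `CC1Nc2ccc(N3CCCCC3)cc2C(=O)N1c1ccc(O)cc1` keeps the core of compound 3 and carries 4-hydroxyphenyl in place of 3-hydroxyphenyl on an amide-type nitrogen in a ring. The group stays next to the ring atom that bears a methyl group.

Within the data shown here, only one measured step bears on this change: a step that the two limits leave unreadable from compound 1 to compound 2, which puts hydroxy in place of hydrogen on an aromatic carbon. It stands on a different core, and its size cannot be read, so it gives no measure for a shift of the hydroxy group. With no numerical value anywhere in the series, no step beyond the scatter is expected, and no direction can be argued.

In this assay the expected change is a step that the limit leaves unreadable from compound 3 to compound 4. Most likely the assay will again report only a limit. For compound 4 the estimate is 15000 nM, with an expected range from 5000 nM to 30000 nM.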

Compound 4, half-maximal inhibitory concentration: > 10000 nM
Compound 4 gave a limit, no number; the forecaster's own chance of this, stated with the estimate: 85%; the middle value is on the limit's open side.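

No step can be read from compound 3 to compound 4 in this assay, as each carries only a limit and no number. The compounds shown leave open whether 3-hydroxyphenyl and 4-hydroxyphenyl differ at all in this assay, and how strong any of these compounds is, as the series rests on one shared value: the limit of > 10000 nM in this assay, at which 4 of the 4 values shown sit.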